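This account rests on a few compounds, and the source may have more. Where it says the series, first, only, none or still open, it means among the compounds named here.

Compound 3 `COc1cc(-c2nn(-c3cccc(NC(=O)Nc4ccc(Cl)c(C(F)(F)F)c4)c3)cc2-c2ccncc2)ccc1Cl` gives 980 nM in a functional assay on CCRF-CEM cells (Homo sapiens) for inhibition, read by sulforhodamine B assay, with a stated time of 48 h; on this read-out higher numbers stand for weaker inhibition of growth and lower numbers for stronger inhibition of growth. Among the three measured numbers it stands lowest, but its gap to compound 2 `O=C(Nc1cccc(-n2cc(-c3ccncc3)c(-c3ccc(Cl)c(O)c3)n2)c1)Nc1ccc(Cl)c(Cl)c1`, which gives 1030 nM, and to compound 1 `O=C(Nc1cccc(-n2cc(-c3ccncc3)c(-c3ccc(Cl)c(O)c3)n2)c1)Nc1cccc(C(F)(F)F)c1`, which gives 1400 nM, lies within the scatter, so the three cannot be ordered. Within the data shown here, the one step measured, a 1.4-fold lower number from compound 1 to compound 2 (0.13 log units; within the scatter), concerns the aryl group on the amide-type nitrogen and also lies within the scatter.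

Compound 4 `O=C(Nc1cccc(-n2cc(-c3ccncc3)c(-c3ccc(Cl)c(O)c3)n2)c1)Nc1ccc(Cl)c(C(F)(F)F)c1` differs from compound 3 by hydrogen in place of methyl on an oxygen on an aromatic ring, that is, methoxy to hydroxy, giving 4-chloro-3-hydroxyphenyl in place of 4-chloro-3-methoxyphenyl. Among the measured compounds shown here, no measured step touches this oxygen. Compounds 1 and 2 carry the hydroxy group and compound 3 the methoxy group, and their values sit within the scatter of one another, which is all the data show. A step of no size beyond the scatter is therefore expected, a 1.0-fold higher number from compound 3 to compound 4 (0.01 log units; within the scatter). Compound 4 is estimated at 1000 nM, between 450 nM and 2200 nM.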

Compound 4, concentration for 50% growth inhibition: 719 nM
Compound 4: the middle estimate sits 1.4-fold (0.14 log units) above what was measured; the range from low to high includes it.
By their numbers in this assay, from the lowest: compounds 4, 3, 2 and 1 (each within the scatter of the next).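

In this assay, the oxygen on the aromatic ring now has a direct reading: hydrogen in place of methyl there gives a 1.4-fold lower number from compound 3 to compound 4 (0.13 log units; within the scatter), so methoxy and hydroxy are not told apart on this core. Two further single changes on the aryl group at the amide-type nitrogen also stay unresolved: trifluoromethyl in place of chloro on an aromatic carbon gives a 1.4-fold lower number from compound 2 to compound 4 (0.16 log units; within the scatter), and chloro in place of hydrogen on an aromatic carbon gives a 1.9-fold lower number from compound 1 to compound 4 (0.29 log units; within the scatter). No supporting data are available to explain any of these results.

The compounds shown leave open whether an amine or a longer chain such as ethoxy in place of the hydroxy group would give a step beyond the scatter. Going by these compounds, it also remains open whether a carboxylic acid on the aryl group at the amide-type nitrogen would do so.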